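The source may hold more compounds than are shown below. What is called first, only, known or untested is meant among the compounds shown, and "the series" means these compounds.

Two compounds have numbers in a functional assay on SH-SY5Y cells (Homo sapiens) for cytotoxicity, with a stated time of 20 h (on this read-out lower numbers stand for higher toxicity in this test and higher numbers for lower toxicity in this test), so far. Compound 1 `Cc1ccc(NC(=O)COc2ccc3cc(/C=C4/SC(=O)NC4=O)ccc3c2)cc1` stands at 49500 nM and compound 2 `O=C(COc1ccc2cc(/C=C3/SC(=O)NC3=O)ccc2c1)Nc1ccc(Br)cc1F` stands at 16000 nM as the lower of the two numbers, which makes it the more toxic of the pair in this test. Compound 3 `Cc1cc(Br)ccc1NC(=O)COc1ccc2cc(/C=C3/SC(=O)NC3=O)ccc2c1` follows from compound 2 through a single change: the exchange methyl in place of fluoro on an aromatic carbon sits on an aromatic carbon, ortho to a large group and meta to a bromo group, with methyl in place of fluoro. Within the data shown here, the only measured step that bears on it is a 3.1-fold lower number from compound 1 to compound 2 (0.49 log units; beyond the scatter) and it is modest. That step put 4-bromo-2-fluorophenyl in place of 4-methylphenyl on an amide-type nitrogen, so bromo and fluoro entered together and the share of the fluoro cannot be read from it. Compound 3 keeps the bromo group of compound 2 and carries a methyl as compound 1 does, so a small move in this assay toward a higher number is expected, possibly within the scatter. The expected step is a 1.5-fold higher number from compound 2 to compound 3 (0.18 log units; within the scatter) on this estimate. For compound 3 the estimated value is 24000 nM with an expected range from 10000 nM to 55000 nM in this read-out.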

Compound 3, half-maximal cytotoxic concentration: 91100 nM
Beside the measured number, compound 3's estimate is 3.8-fold (0.58 log units) below it; measured number above the stated range.
By their numbers in this assay, from the lowest: compound 2; then compounds 1 and 3 (each within the scatter of the next).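

In this assay the exchange of methyl for fluoro on an aromatic carbon, ortho to a large group and meta to a bromo group, gives a 5.7-fold higher number from compound 2 to compound 3 (0.76 log units; beyond the scatter) and so isolates this one position as able to carry a step beyond the scatter, which the earlier pair could not show with bromo and fluoro entering together. The change of the aromatic group on the amide-type nitrogen gives a 1.8-fold higher number from compound 1 to compound 3 (0.26 log units; within the scatter) and lies within the scatter, so the bromo group does not go with a lower number in every compound and, of these three, only compound 2 with its fluoro stands apart as the most toxic in this test. No measurement at hand accounts for the size of the exchange at this position.

As far as these compounds go, whether the exchange moves the number to the same extent without the bromo group remains open. Also open, from the compounds shown here alone, is how this position reads with chloro, methoxy or an amine in place of fluoro or methyl, and whether the hydrogen compound would fall nearer compound 2 or compound 3.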